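The compounds below may be only part of what the source reports. "The series", "measured", "known", "first", "only" and "open" are said of these compounds alone.

Of the compounds shown here, three of one shared core have been measured in an assay on isolated protein for displacement of a labelled ligand from metabotropic glutamate receptor 5 (Homo sapiens), with a stated time of 60 min, tested at 1 uM; a higher number here means more inhibition at the concentration tested (going by the name of the read-out), a lower number less inhibition. Compound 1 `CC1CCN(c2c(S(=O)(=O)c3cc(F)cc(F)c3)cnc3cc(Cl)ccc23)CC1` gives 94%. Compound 2 `CC1CCN(c2c(S(=O)(=O)c3cc(F)cc(F)c3)cnc3cc(F)ccc23)CC1` gives 77%, and compound 3 `NS(=O)(=O)N1CCN(c2c(S(=O)(=O)c3cc(F)cc(F)c3)cnc3cc(F)ccc23)CC1` gives 6.4%. Compound 2 therefore stands second of the three: swapping chloro for fluoro on an aromatic carbon gave a number 17 percentage points lower from compound 1 to compound 2 (beyond the scatter), while replacing 4-methylpiperidin-1-yl with 4-sulfamoylpiperazin-1-yl on an aromatic carbon gave a number 70.6 percentage points lower from compound 2 to compound 3 (beyond the scatter), so compound 2 sits well below compound 1 and far above compound 3.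

The step now followed leads from compound 2 to compound 4 `Cc1ccc(S(=O)(=O)c2cnc3cc(F)ccc3c2N2CCC(C)CC2)cc1C`. The difference is 3,4-dimethylphenyl in place of 3,5-difluorophenyl on a sulfonyl sulfur. Neither measured step touches this part of the molecule: one changed a halogen on the core, the other the amine ring, so neither directly shows what changing the ring on the sulfonyl sulfur does. Among the compounds with values here, the only guidance is that a small change on the core moved this assay modestly and a large change on the amine ring moved it greatly; swapping the halogens of the 3,5-difluorophenyl for the methyls of 3,4-dimethylphenyl is a change of intermediate size, so a drop below compound 2 is expected, with wide uncertainty. Compound 4 is estimated to reach 58%, between 20% and 90%, an expected step of a number 19 percentage points lower from compound 2 to compound 4 (beyond the scatter).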

Compound 4, a percentage reported as inhibition, at one concentration (the size of the read-out at that concentration, not a potency): 90%
The estimate for compound 4 lay 32 percentage points below the measured number; the measured number falls inside the stated range.
By their numbers in this assay, from the lowest: compound 3; then compound 2; then compounds 4 and 1 (each within the scatter of the next).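

On the ring held by the sulfonyl sulfur, the first change seen at this position gives, in this assay, a number 13 percentage points higher from compound 2 to compound 4 (beyond the scatter). The two fluorines of 3,5-difluorophenyl are therefore not needed to keep a high number at the concentration tested: 3,4-dimethylphenyl, which contains only carbon, gives a higher number here, although both groups have the same heavy-atom count, one six-membered aromatic ring of carbon only, and no hydrogen-bond donors or acceptors. Nothing measured explains the difference between these two groups, so the step stands as an observation only.

With only these two substituted phenyl rings on the sulfonyl sulfur among the compounds shown, it remains open whether a single methyl, a methoxy group or a pyridine ring in place of the phenyl would hold the number. On these data alone, it is also open whether 3,4-dimethylphenyl would bring a similar change on the chloro core of compound 1 or alongside the 4-sulfamoylpiperazin-1-yl group of compound 3.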